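Ester to acid on a fluorene-type core: one step, one repeat

The source may report more compounds than this note shows. Statements on the series, on what has been measured and on what is new or still open speak of the compounds shown alone.

Four compounds share a tricyclic core that carries a methyl ester or a carboxylic acid. Compound 1, `COC(=O)c1ccc2c(C(=O)c3ccccc3)cc(C(=O)c3ccccc3)c-2cc1`, has the methyl ester and two benzoyl groups; compound 2, `O=C(O)c1ccc2c(C(=O)c3ccccc3)cc(C(=O)c3ccccc3)c-2cc1`, is its acid. Compound 3, `COC(=O)c1ccc2ccc(C=O)c-2cc1`, keeps the methyl ester but carries an aldehyde in place of the two benzoyl groups; how the core of compound 3 differs from the core of compound 1 is not broken down here. Compound 4, `O=Cc1ccc2ccc(C(=O)O)ccc1-2`, is the acid of compound 3.

In an assay on cells for displacement of a labelled ligand from Orexin receptor type 2 (Homo sapiens), read by scintillation counting, with stated times of 10 min and 90 min, tested at 10 uM (a lower number here means less inhibition, a higher number more inhibition at the concentration tested (going by the name of the read-out)), compound 1 gives -14.5%, compound 2 gives 27%, and compound 3 gives 37.2%.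

The change from compound 1 to compound 2 is hydrogen in place of methyl on an oxygen next to a carbonyl group. It brought a number 41.5 percentage points higher from compound 1 to compound 2 (beyond the scatter), a large step that is beyond the usual scatter of this assay.

The change from compound 3 to compound 4 is hydrogen in place of methyl on an oxygen next to a carbonyl group, the same kind of change at the same kind of place, made once more on a different core. Among the compounds with values here, only one earlier example of it is available, so the step it will make on the core of compound 3 is uncertain.

Compound 4 is estimated to give about 55% in this assay, with a likely range from 30% to 80%. That estimate means an expected a number 17.8 percentage points higher from compound 3 to compound 4 (beyond the scatter), a gain smaller than the earlier one, because compound 2 already showed a number 41.5 percentage points higher from compound 1 to compound 2 (beyond the scatter) from a lower starting point than compound 3.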

Compound 4, a percentage reported as inhibition, at one concentration (the size of the read-out at that concentration, not a potency): 44.1%
Beside the measured number, compound 4's estimate is 10.9 percentage points above it; the measured number falls inside the stated range.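

On the core of compound 3, replacing methyl with hydrogen on the oxygen next to the carbonyl group, which turns methoxycarbonyl into carboxy, gives in this assay a number 6.9 percentage points higher from compound 3 to compound 4 (within the scatter), so this pair shows no change that can be told from ordinary repeat variation. Set beside the earlier pair, the same change does not carry over at the same size from one core to the other: the same change on two cores in this assay, a number 41.5 percentage points higher (beyond the scatter) from compound 1 to compound 2 and a number 6.9 percentage points higher (within the scatter) from compound 3 to compound 4, 34.6 percentage points apart, beyond the scatter of two such steps

Within the data shown here, this shows that the large step seen on the core of compound 1 cannot be assumed on another core, but it does not show what sets the two cores apart, as they differ in more than one place and there are only two pairs, each read at a single concentration that gives no potency. The compounds shown leave open how other groups at this place, such as an amide or an ethyl ester, would read on either core. They also leave open whether the benzoyl groups, the aldehyde or some other part of the core goes with the difference between the steps, and a compound carrying a single benzoyl group could begin to separate these.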